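A few compounds are considered here, and "the series" means these few. Any claim that something is new, unique, unknown or untested is made for them only; others in the source may bear on it.

Measured in a functional assay on OVCAR-3 cells (Homo sapiens) for antiproliferative activity, read by sulforhodamine B assay, with a stated time of 48 h; a higher number here means a weaker inhibitor of growth, a lower number a stronger inhibitor of growth:
Compound 1 `CCCCCC[C@@H](O)C/C=C\CCCCCCCC(=O)N1CCOCC1`: 31 ug/mL
Compound 2 `CCCCCCCC/C=C\CCCCCCCC(=O)N1CCCCC1`: 9.3 ug/mL

Compound 2 stands lower of the two, and its gap to compound 1 lies beyond the scatter. Compound 3 `CCCCCCCC/C=C\CCCCCCCC(=O)N1CCOCC1` has morpholin-4-yl in place of piperidin-1-yl on a carbonyl carbon. Within the data shown here, no measured pair isolates this change in this assay, so the expectation rests on thin evidence. Compound 1, which also carries morpholin-4-yl, gives 31 ug/mL, so a modest move toward a higher number, meaning weaker growth inhibition, is expected. The expected step is a 1.7-fold higher number from compound 2 to compound 3 (0.24 log units; within the scatter). For compound 3 the estimated value is 16 ug/mL, with an expected range of 7 ug/mL to 35 ug/mL.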

Compound 3, concentration for 50% growth inhibition: 4.9 ug/mL
For compound 3 the middle estimate is 3.3-fold (0.51 log units) above the measured one; measured number outside the range, below it.
By their numbers in this assay, from the lowest: compounds 3 and 2 (each within the scatter of the next); then compound 1.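

In this assay, morpholin-4-yl in place of piperidin-1-yl on a carbonyl carbon gives a 1.9-fold lower number from compound 2 to compound 3 (0.28 log units; within the scatter), so this exchange does not separate the two amides. Hydrogen in place of hydroxy on the saturated chain carbon gives a 6.3-fold lower number from compound 1 to compound 3 (0.80 log units; beyond the scatter), which shows that, with morpholin-4-yl held constant, the chain hydroxy carries a real difference. Nothing available explains either step. As far as these compounds go, whether the hydroxy has the same effect with piperidin-1-yl on the carbonyl carbon remains open. So does the outcome with a diethylamino group there, or with a carboxylic acid replacing the amide.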